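The source may report more compounds than this note shows. Statements on the series, on what has been measured and on what is new or still open speak of the compounds shown alone.

Compound 1, `COc1ccccc1/C=c1/[nH]c(=O)/c(=C\c2ccccc2OC)[nH]c1=O`, gave "not active" (no number reported) in a functional assay on U-937 cells (Homo sapiens) for cytotoxicity, read by CCK-8 assay, with a stated time of 72 h; on this read-out higher numbers stand for weaker inhibition and lower numbers for stronger inhibition. Compound 2, `COc1ccccc1/C=c1\c(=O)[nH]/c(=C/c2cccc(Cl)c2Cl)c(=O)n1C`, reaches 100 nM in this assay, while compound 3, `C=CCn1c(=O)/c(=C\c2cccc(F)c2)[nH]c(=O)/c1=C\c1ccccc1OC`, gives 2500 nM. Compound 3 thus holds the highest of the two numbers; the gap down to compound 2 lies beyond the scatter, although the two differ in more than one place, so no single change can be credited. Compound 4, `C=CCn1c(=O)/c(=C\c2ccc(F)c(Br)c2)[nH]c(=O)/c1=C\c1ccccc1OC`, has not been measured. It differs from compound 3 by 3-bromo-4-fluorophenyl in place of 3-fluorophenyl on a double-bonded chain carbon bound to an aromatic carbon. For the measured compounds named here, no measured pair isolates such a change here. The step from compound 3 to compound 4 is expected to be small, estimated at a 2.1-fold lower number from compound 3 to compound 4 (0.32 log units; beyond the scatter) toward a lower number and not clearly beyond the scatter. Compound 4 is therefore expected to give about 1200 nM, within 300 nM to 5000 nM.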

Compound 4, half-maximal inhibitory concentration: "not active" (no number reported)
Compound 4 has no reported number here, and the estimate cannot be compared.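

With no number for compound 4, no step from compound 3 can be read, and no evidence at hand explains this result. Going by these compounds, how far 3-bromo-4-fluorophenyl alone shifts the cytotoxicity read-out stays open.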